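The source may hold more compounds than are shown below. What is called first, only, known or untested is meant among the compounds shown, and "the series" means these compounds.

Working notes on the series, read in a functional assay on HCT-116 cells (Homo sapiens) for antiproliferative activity, read by MTT assay, with a stated time of 24 h; a lower number here means a stronger inhibitor, a higher number a weaker inhibitor. For the measured compounds named here, compound 1 (`COc1cc(OC)c(-c2coc3cc(OCc4ccc(C#N)cc4)ccc3c2=O)cc1OC`) gives 4220 nM, and compound 2 (`COc1cc(OC)c(-c2coc3cc(OCc4cccc(Cl)c4)ccc3c2=O)cc1OC`) gives 1330 nM, the lower of the two numbers so far. The next compound is compound 3 (`COc1cc(OC)c(-c2coc3cc(OCc4cccc(Br)c4)ccc3c2=O)cc1OC`), not yet measured, and the change from compound 2 is bromo in place of chloro on an aromatic carbon, meta to a large group, which also reads as 3-chlorobenzyl to 3-bromobenzyl.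

Going by the values given here, only one measured step bears on this change, and only loosely: a 3.2-fold lower number from compound 1 to compound 2 (0.50 log units; beyond the scatter), with 3-chlorophenyl in place of 4-cyanophenyl. That step exchanged a different group and moved its place on the ring, whereas the new change keeps the place and exchanges one halogen for another. Among the compounds with values here, no measured pair tests such an exchange, so the size of that step is not carried over and no direction is firmly expected. The estimated step, a 1.1-fold lower number from compound 2 to compound 3 (0.03 log units; within the scatter), is expected to stay within the scatter. For compound 3 the estimated value is 1250 nM, with an expected range of 620 nM to 2500 nM.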

Compound 3, half-maximal inhibitory concentration: 1200 nM
Compound 3: middle estimate off by 1.0-fold (0.02 log units), on the high side, and the stated range covers the measured number.
By their numbers in this assay, from the lowest: compounds 3 and 2 (each within the scatter of the next); then compound 1.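

In this assay the exchange of one halogen for another at this place gets its first direct test, and a 1.1-fold lower number from compound 2 to compound 3 (0.04 log units; within the scatter) leaves compound 2 and compound 3 at one level, so chloro and bromo cannot be told apart on this aromatic carbon. The second halogen also repeats the separation from the nitrile-bearing group, with a 3.5-fold lower number from compound 1 to compound 3 (0.55 log units; beyond the scatter) standing alongside a 3.2-fold lower number from compound 1 to compound 2 (0.50 log units; beyond the scatter) and both steps beyond the scatter, so the two 3-halobenzyl compounds share a lower reading than the nitrile compound, and none of the three compounds goes against this. No supporting measurement is available to explain why the two halogens read alike or why the nitrile compound reads higher.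

The compounds shown leave open whether the level belongs to halogens in particular, as a fluoro, methyl, methoxy or amine group at the same place could separate that reading from a more general tolerance of this position. They also do not separate the effect of the group from that of its place, as a 4-chlorobenzyl or 3-cyanobenzyl compound would, and the unsubstituted benzyl group is absent as a reference.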